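A few compounds are considered here, and "the series" means these few. Any claim that something is new, unique, unknown or untested is made for them only; others in the source may bear on it.

Working notes on a small set of dihydropyrimidinethione carboxamides. Compound 1 `CC1=C(C(=O)Nc2ccc(Cl)c(Cl)c2)C(c2cccc(O)c2)NC(=S)N1`, compound 2 `CC1=C(C(=O)Nc2ccc(F)c(Cl)c2)C(c2cccc(Oc3ccccc3)c2)NC(=S)N1` and compound 3 `CC1=C(C(=O)Nc2ccc(Cl)c(Cl)c2)C(c2cccc(Oc3ccccc3)c2)NC(=S)N1` have been run in a functional assay on SK-MEL-5 cells (Homo sapiens) for cytotoxicity, read by sulforhodamine B assay, with a stated time of 48 h; a higher number here means a weaker inhibitor of growth, a lower number a stronger inhibitor of growth. Compound 1 gives 10000 nM, compound 2 gives 8910 nM, and compound 3 gives 7940 nM; all three sit within the scatter of one another, so no order among them can be read. The two cores differ by fluoro in place of chloro on an aromatic carbon, and the corresponding step, a 1.1-fold lower number from compound 2 to compound 3 (0.05 log units; within the scatter), is flat. The change from compound 3 to compound 1 is hydrogen in place of phenyl on an oxygen on an aromatic ring, giving a 1.3-fold higher number from compound 3 to compound 1 (0.10 log units; within the scatter), again flat.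

Compound 4 `CC1=C(C(=O)Nc2ccc(F)c(Cl)c2)C(c2cccc(O)c2)NC(=S)N1` has not yet been measured in this assay. It differs from compound 2 by hydrogen in place of phenyl on an oxygen on an aromatic ring, the same change as from compound 3 to compound 1, at a place described in identical words. Going by the values given here, on the single precedent, where compound 3 to compound 1 moved by a 1.3-fold higher number from compound 3 to compound 1 (0.10 log units; within the scatter), the step from compound 2 to compound 4 is expected to be about a 1.2-fold higher number from compound 2 to compound 4 (0.09 log units; within the scatter). Compound 4 is therefore estimated at 11000 nM in this assay, likely between 5000 nM and 25000 nM, with weak growth inhibition expected because compound 2 already gives 8910 nM.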

Compound 4, concentration for 50% growth inhibition: 11200 nM
For compound 4 the middle estimate is 1.0-fold (0.01 log units) below the measured one; measured number inside the range.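

In this assay, hydrogen in place of phenyl on an oxygen on an aromatic ring gives a 1.3-fold higher number from compound 2 to compound 4 (0.10 log units; within the scatter), and this step matches the earlier one on the other core: the same change on two cores in this assay, a 1.3-fold higher number (0.10 log units; within the scatter) from compound 3 to compound 1 and a 1.3-fold higher number (0.10 log units; within the scatter) from compound 2 to compound 4, 1.0-fold (0.00 log units) apart, within the scatter of two such steps

The halogen change also carries over, with fluoro in place of chloro on an aromatic carbon giving a 1.1-fold higher number from compound 1 to compound 4 (0.05 log units; within the scatter), which matches its earlier counterpart: the same change on two cores in this assay, a 1.1-fold lower number (0.05 log units; within the scatter) from compound 2 to compound 3 and a 1.1-fold lower number (0.05 log units; within the scatter) from compound 4 to compound 1, 1.0-fold (0.00 log units) apart, within the scatter of two such steps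

This shows that both changes stay flat on the two cores, which differ only by one halogen, but every step lies within the scatter, so the agreement is between null results and does not show that a measurable effect transfers from one core to another.

From the compounds shown here alone, it remains open whether a group other than phenoxy or hydroxy at this place, such as methoxy, an amine or a carboxylic acid, would move the number beyond the scatter. Going by these compounds, it is equally open whether replacing the chloro and fluoro groups with a nitrile or trifluoromethyl group would do so.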